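Pyridin-4-yl for phenyl on the benzamide of compound 1

The compounds below may be only part of what the source reports. "The series", "measured", "known", "first", "only" and "open" are said of these compounds alone.

Compound 1 `O=C(Nc1cc(C(F)(F)F)ccc1NC1CCCCC1)c1ccccc1` carries a cyclohexylamino group on the shared core and a benzamide. In a functional assay on Jurkat cells (Homo sapiens) for cytotoxicity, read by MTT assay, with a stated time of 48 h (a higher number here means a weaker inhibitor, a lower number a stronger inhibitor), compound 1 gives "not active" (no number reported), so no single number places it on the scale. For the measured compounds named here, compound 2 `O=C(Nc1cc(C(F)(F)F)ccc1Nc1ccc(Br)cc1)c1ccccc1` differs in more than one place, with a bromophenyl in place of the cyclohexyl, and in this assay compound 2 gives 33800 nM; with no step computed between compound 1 and compound 2, the two values show only that one is reported as a number and the other is not.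

Compound 3 `O=C(Nc1cc(C(F)(F)F)ccc1NC1CCCCC1)c1ccncc1` is the next compound to be measured. It differs from compound 1 in one place: pyridin-4-yl in place of phenyl on a carbonyl carbon. Going by the values given here, no step between measured compounds is known for this change, so the size of its effect in this assay is not anchored. Given that compound 1 gives "not active" (no number reported), the expectation is a small step at most, in either direction or none beyond the scatter, with a weak result remaining likely. For compound 3 in this assay the estimate is 60000 nM, within 20000 nM to 200000 nM, with a substantial chance that only a limit is reported.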

Compound 3, half-maximal inhibitory concentration: 80900 nM
The estimate for compound 3 lay 1.3-fold (0.13 log units) below the measured number; the range from low to high includes it.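

In this assay, for the compounds shown here, compound 1 gives "not active" (no number reported) and compound 3 gives 80900 nM so no step from one to the other can be read. The compounds shown leave open how large the effect of pyridin-4-yl in place of phenyl is in this series. No available evidence bears on this result.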